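The source may report more compounds than this note shows. Statements on the series, on what has been measured and on what is new or still open speak of the compounds shown alone.

Compound 1 `O=C1/C(=C\c2ccccc2)C(c2ccccc2)Oc2ccccc21` gives 3.9
Compound 2 `O=C1/C(=C/c2ccccc2)C(c2ccccc2)Oc2ccccc21` gives 3.9

In a physicochemical assay for lipophilicity, read by HPLC (on this read-out lower numbers stand for lower lipophilicity and higher numbers for higher lipophilicity), compound 1 stands level with compound 2. Within the data shown here, the only measured step (no change at the digits printed from compound 1 to compound 2 (within the scatter)) concerns the geometry of a double bond and adds no new group. Compound 3 `O=C1/C(=C\c2ccc(Br)cc2)C(c2ccccc2)Oc2ccccc21` keeps the core of compound 1 but carries bromo in place of hydrogen on an aromatic carbon para to a large group. The measured step therefore gives no size for this change, so the expectation is only a rough one: an estimated rise (a number 0.70 log units higher from compound 1 to compound 3 (beyond the scatter)) beyond the scatter. For compound 3 the estimated value is 4.6 (expected range 4.2 to 5).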

Compound 3, partition coefficient: 4.71
Compound 3: middle estimate off by 0.11 log units, on the low side; the range from low to high includes it.
By their numbers in this assay, from the lowest: compounds 1 and 2 (each within the scatter of the next); then compound 3.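

Replacing hydrogen with bromo on an aromatic carbon, para to a large group, gives a number 0.81 log units higher from compound 1 to compound 3 (beyond the scatter) in this assay. This shows that the read-out responds to a change at this position, whereas the double-bond geometry step gave no change at the digits printed from compound 1 to compound 2 (within the scatter). Nothing available here explains the size of this rise.

One group at one position sets no trend. On these data alone, how chloro, methyl, an amine or a carboxylic acid in this place would read in this assay remains open, as does whether bromo elsewhere on this ring would give a similar step.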